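The compounds below may be only part of what the source reports. "The series", "measured", "known", "first", "only" and "open" are said of these compounds alone.

Measured compounds:
Compound 1, `COc1cncc(-c2ccnc3c2c(C(C)C)nn3-c2ccc(C(N)=O)c(N[C@H]3CC[C@H](O)CC3)c2)c1`, gives 451 nM in a functional assay on SK-BR-3 cells (Homo sapiens) for inhibition, read by CellTiter-Glo, with a stated time of 72 h; on this read-out lower numbers stand for stronger inhibition and higher numbers for weaker inhibition.
Compound 2, `CC(C)c1nn(-c2ccc(C(N)=O)c(N[C@H]3CC[C@H](O)CC3)c2)c2nccc(-n3cnc(-c4cncnc4)c3)c12`, gives 387 nM in this assay.

Among the measured compounds shown here, compound 2 holds the lower of the two numbers, but its only neighbour, compound 1, lies within the scatter of it, so no order between the two can be claimed. Compound 3, `CC(C)c1nn(-c2ccc(C(N)=O)c(N[C@H]3CC[C@H](O)CC3)c2)c2nccc(-c3ccccc3)c12`, has not yet been tested in this assay. It differs from compound 2 in one place: phenyl in place of 4-(pyrimidin-5-yl)-1H-imidazol-1-yl on an aromatic carbon. For the measured compounds named here, only one measured step bears on this position of the shared core, a 1.2-fold lower number from compound 1 to compound 2 (0.07 log units; within the scatter), and it shows that exchanging one group for another there left the read-out essentially unchanged. That step, however, swapped two groups that both carry hydrogen-bond acceptors, whereas the change to compound 3 removes them altogether, so the precedent covers it only loosely. Resting on that single step, compound 3 is expected to stay close to compound 2, with a step of a 1.8-fold higher number from compound 2 to compound 3 (0.26 log units; within the scatter), a slight weakening that may not clear the scatter. Compound 3 is therefore estimated at 700 nM, within a range from 250 nM to 2500 nM.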

Compound 3, half-maximal inhibitory concentration: > 10000 nM
Compound 3 was reported as a limit; the forecaster's own chance of this, stated with the estimate: 5%; at least 14-fold (1.15 log units) between middle value and limit.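

Compound 3 sits at a limit of this assay, so its entry is a limit and not a number: the limit of > 10000 nM in this assay, at which 1 of the 3 values shown sits. This position now proves sensitive to what it carries: phenyl in place of 4-(pyrimidin-5-yl)-1H-imidazol-1-yl gives an at least 25-fold higher number from compound 2 to compound 3 (1.41 log units; beyond the scatter), and phenyl in place of 5-methoxypyridin-3-yl gives an at least 22-fold higher number from compound 1 to compound 3 (1.34 log units; beyond the scatter), both large steps. The earlier exchange, a 1.2-fold lower number from compound 1 to compound 2 (0.07 log units; within the scatter), had shown only that two groups containing ring nitrogen could replace each other within the scatter, whereas the new result shows that this tolerance does not extend to an aromatic ring of carbon only.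

On these data alone, the true size of both steps stays open, as does the question of whether the loss follows from the missing ring nitrogen or from some other difference between phenyl and the two groups it replaces. A plain pyridin-3-yl group, or a phenyl ring carrying a methoxy group or an amine, at this same position would help to separate these possibilities.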